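Carbonyl aryl variation on the shared core, cytotoxicity notes

The source may report more compounds than this note shows. Statements on the series, on what has been measured and on what is new or still open speak of the compounds shown alone.

Measured so far in a functional assay on MCF7 cells (Homo sapiens) for cytotoxicity, read by MTT assay, with a stated time of 48 h; a lower number here means a stronger inhibitor, a higher number a weaker inhibitor:
compound 1 `COc1cc(-c2nnc3n2NC(c2ccco2)C(C(=O)c2ccco2)S3)cc(OC)c1OC` — a limit only, > 100000 nM
compound 2 `COc1cc(-c2nnc3n2NC(c2ccco2)C(C(=O)c2ccccc2F)S3)cc(OC)c1OC` — 94800 nM
compound 3 `COc1cc(-c2nnc3n2NC(c2ccco2)C(C(=O)c2ccc(-c4ccccc4)cc2)S3)cc(OC)c1OC` — a limit only, > 100000 nM

Within the data shown here, compound 3 sits at the assay limit, as does compound 1, and compound 2 is the only one with a number, one that lies within the scatter of that limit. The step that the two limits leave unreadable from compound 1 to compound 3 is therefore unreadable, while an at least 1.0-fold higher number from compound 2 to compound 3 (0.02 log units; that floor lies within the scatter) and an at least 1.0-fold lower number from compound 1 to compound 2 (0.02 log units; that floor lies within the scatter) both stay within the scatter; none of the three changes on the carbonyl carbon moved the read-out beyond the scatter, as the limit of > 100000 nM in this assay, at which 2 of the 3 values shown sit, shows.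

Compound 4 `COc1cc(-c2nnc3n2NC(c2ccco2)C(C(=O)c2ccccc2)S3)cc(OC)c1OC` takes the next cut on the same carbonyl aryl: hydrogen in place of phenyl on an aromatic carbon. The measured steps around this position carry no readable signal, so no movement beyond the scatter is expected in this assay, and the read-out is likely to remain a limit. Compound 4 is estimated at 100000 nM, within 50000 nM to 200000 nM, meaning an expected step of a number no higher from compound 3 to compound 4 (the limit leaves the size open).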

Compound 4, half-maximal inhibitory concentration: 39800 nM
Compound 4: the middle estimate sits 2.5-fold (0.40 log units) above what was measured, outside the stated range (below it).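

In this assay the carbonyl aryl now gives a readable response: hydrogen in place of phenyl on an aromatic carbon gives an at least 2.5-fold lower number from compound 3 to compound 4 (0.40 log units; beyond the scatter), and plain phenyl in place of 2-fluorophenyl gives a 2.4-fold lower number from compound 2 to compound 4 (0.38 log units; beyond the scatter), so both groups on the plain phenyl ring go with a weaker read-out here. Phenyl in place of furan-2-yl on a carbonyl carbon gives an at least 2.5-fold lower number from compound 1 to compound 4 (0.40 log units; beyond the scatter), which leaves compound 4 as the strongest of the four, with every step to it beyond the scatter. The steps from compound 1 and from compound 3 are floors and not sizes: the limit of > 100000 nM in this assay, at which 2 of the 4 values shown sit.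

Open, on these data alone, is whether other groups on this phenyl ring, such as methoxy, an amine or a carboxylic acid, also go with a weaker read-out. Also open, as far as these compounds go, is how the read-out responds when a pyridine replaces the remaining furan-2-yl on the shared core.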